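This account rests on a few compounds, and the source may have more. Where it says the series, first, only, none or still open, it means among the compounds named here.

Compound 1 `[O-]/[N+](=C\c1cn(-c2ccc(F)cc2)nn1)c1ccccc1` is one of a small set of compounds tested in a functional assay on MDA-MB-231 cells (Homo sapiens) for inhibition, read by MTT assay, with a stated time of 24 h (on this read-out lower numbers stand for stronger inhibition and higher numbers for weaker inhibition), where compound 1 gives 9800 nM, the higher of the two numbers available. Compound 2 `[O-]/[N+](=C\c1cn(-c2ccc(Cl)cc2)nn1)c1ccccc1` gives 8900 nM in this assay. Among the compounds with values here, the only measured single change, a 1.1-fold lower number from compound 1 to compound 2 (0.04 log units; within the scatter), therefore tells little. Compound 3 `[O-]/[N+](=C\c1cn(CCC(F)(F)C(F)(F)C(F)(F)C(F)(F)C(F)(F)C(F)(F)C(F)(F)C(F)(F)F)nn1)c1ccccc1` yields only a limit in this assay, > 100000 nM. That value is the limit of > 100000 nM in this assay, at which 1 of the 3 values shown sits.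

Compound 4 `[O-]/[N+](=C\c1cn(-c2ccc(F)cc2)nn1)Cc1ccccc1` differs from compound 1 by benzyl in place of phenyl on a double-bonded nitrogen. Within the data shown here, no measured step touches that position, and the one measured step stayed within the scatter, so there is no basis for expecting a shift beyond it. The expected step is no change at the digits printed from compound 1 to compound 4 (within the scatter). Compound 4 is thus estimated at 9800 nM, between 4000 nM and 25000 nM.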

Compound 4, half-maximal inhibitory concentration: > 100000 nM
Compound 4 was reported as a limit; the forecaster's own chance of this, stated with the estimate: 10%; middle value at least 10-fold (1.00 log units) from the limit.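

Benzyl in place of phenyl on the double-bonded nitrogen gives an at least 10-fold higher number from compound 1 to compound 4 (1.00 log units; beyond the scatter). Within the data shown here, the earlier step changed only the halogen on the other aryl ring, so this is the first sign that this assay responds to a change at this nitrogen, even one as small as a single added carbon. The result for compound 4 is a limit, not a number, so the full size of the loss stays unknown: the limit of > 100000 nM in this assay, at which 2 of the 4 values shown sit.

Still open, going by these compounds, is whether a methyl group or a phenyl ring carrying a methoxy group on this nitrogen would keep a number close to that of compound 1.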